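A few compounds are considered here, and "the series" means these few. Any claim that something is new, unique, unknown or untested is made for them only; others in the source may bear on it.

Measured so far, each in the same test:
Compound 1, `C=CC1=C(C(=O)Nc2ccccc2)C(c2ccc(Cl)c(Cl)c2)OC1`, gives a limit of > 100000 nM.
Compound 2, `C=CC1=C(C(=O)Nc2ccc(C)cc2)C(c2ccc(F)cc2)OC1`, gives a limit of > 100000 nM.
Compound 3, `C=CC1=C(C(=O)NCc2ccccc2F)C(c2ccc(F)cc2)OC1`, gives a limit of > 100000 nM.

All three were run in a functional assay on HeLa cells (Homo sapiens) for cytotoxicity, read by MTT assay, with a stated time of 24 h; on this read-out higher numbers stand for weaker inhibition and lower numbers for stronger inhibition. Compound 3 stands at the edge of what the test can report: its value is a limit, not a number, and the same holds for the other two, because of the limit of > 100000 nM in this assay, at which 3 of the 3 values shown sit. Within the data shown here, the one step between measured compounds, a step that the two limits leave unreadable from compound 2 to compound 3, is therefore unreadable; the change there was a 2-fluorobenzyl group in place of a 4-methylphenyl group on the amide-type nitrogen, and the two limits cannot say whether it helped or hurt.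

Compound 4, `C=CC1=C(C(=O)Nc2ccccc2)C(c2ccc(F)cc2)OC1`, has not yet been measured. It differs from compound 3 in one place: phenyl in place of 2-fluorobenzyl on an amide-type nitrogen. Among the measured compounds shown here, nothing measured so far bears on this change except that every compound carrying a different group on that nitrogen sat at the limit, so no step beyond the scatter is expected in this assay in either direction. Compound 4 is expected to sit at or near the same limit, giving an estimated 150000 nM, in the range 50000 nM to 500000 nM, which amounts to an expected step that the limit leaves unreadable from compound 3 to compound 4.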

Compound 4, half-maximal inhibitory concentration: > 100000 nM
Compound 4: a limit, no number; the forecaster's own chance of this, stated with the estimate: 85%; the middle value is on the limit's open side.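

Compound 4 gives > 100000 nM as a limit, not a number. Among these compounds, no step among compound 1, compound 2, compound 3 and compound 4 can be read, since none of the four has a measured number to compare. The compounds shown leave open how strongly any of them acts on these cells, and whether any of the changes between them matters.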